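The source may report more compounds than this note shows. Statements on the series, on what has been measured and on what is new or still open speak of the compounds shown alone.

In a functional assay on NCI-H226 cells (Homo sapiens) for cytotoxicity, read by sulforhodamine B assay, with a stated time of 48 h, tested at 10 uM (on this read-out lower numbers stand for a stronger effect and higher numbers for a weaker effect at the one concentration tested), three compounds have been measured. Compound 1 `COc1ccc(-c2cc(/C=C/C(=O)c3ccc(OC)c(OC)c3)[nH]n2)cc1` gives -64%, compound 3 `COc1ccc(-c2cc(/C=C/C(=O)c3ccc(N)cc3)[nH]n2)cc1OC` gives -13%, and compound 2 `COc1cc(-c2cc(/C=C/C(=O)c3ccc(Cl)c(Cl)c3)[nH]n2)cc(OC)c1OC` gives 67%. Compound 2 stands highest of the three numbers in this assay: its nearest neighbour is compound 3, whose number lies beyond the scatter below it, and the furthest is compound 1, further still below it and likewise beyond the scatter.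

The step considered here leads from compound 2 to compound 4 `COc1ccc(C(=O)/C=C/c2cc(-c3cc(OC)c(OC)c(OC)c3)n[nH]2)cc1OC`, which has not yet been measured. The change is 3,4-dimethoxyphenyl in place of 3,4-dichlorophenyl on a carbonyl carbon. Only the group on the carbonyl carbon differs; the rest of the two structures is the same.

Going by the values given here, no pair of measured compounds differs in a single place, so there is no measured step to lean on. Compound 1, which also carries a 3,4-dimethoxyphenyl on its carbonyl carbon, gives -64%, far below the number of compound 2. On that basis the step of a number 92 percentage points lower from compound 2 to compound 4 (beyond the scatter) is expected to be large and downward, well beyond the scatter. Compound 4 is therefore estimated at -25%, with a range from -70% to 35% in this assay.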

Compound 4, a percentage reported as activity, at one concentration (the size of the read-out at that concentration, not a potency): -81%
Estimate against measurement, compound 4: 56 percentage points above; measured number outside the range, below it.
By their numbers in this assay, from the lowest: compound 4; then compound 1; then compound 3; then compound 2.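

Going by these compounds alone, this step gives the first direct reading of the group on the carbonyl carbon, since none of the earlier compounds differed from one another in a single place. In this assay, 3,4-dimethoxyphenyl in place of 3,4-dichlorophenyl gives a number 148 percentage points lower from compound 2 to compound 4 (beyond the scatter), with the read-out passing from the positive side in compound 2 at 67% to the negative side in compound 4 at -81%, so this one exchange on an otherwise unchanged structure is enough to move the number from a weak effect to a strong one at the single concentration tested. Nothing available explains why the two groups differ so widely.

With only one pair, the compounds shown cannot tell whether the step follows from the loss of the chlorine atoms or from the arrival of the methoxy groups, and they leave open how an unsubstituted phenyl or a phenyl bearing a carboxylic acid would read on the carbonyl carbon. Going by these compounds, whether the same exchange would keep its size on a different core also remains open, and each number describes only a stronger or weaker effect at the one concentration tested.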